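The source may hold more compounds than are shown below. What is called first, only, known or untested is meant among the compounds shown, and "the series" means these compounds.

Compound 1 `CN1C/C(=C\c2ccc(C(C)(C)C)cc2)C(=O)/C(=C/c2ccccc2F)C1` gives 18200 nM
Compound 2 `CN1C/C(=C\c2ccc(C(F)(F)F)cc2)C(=O)/C(=C/c2ccccc2F)C1` gives 6340 nM
Compound 3 `CN1C/C(=C\c2ccc(C#N)cc2)C(=O)/C(=C/c2ccccc2F)C1` gives 2670 nM

In a functional assay on K562 cells (Homo sapiens) for cytotoxicity, read by MTT assay, with a stated time of 24 h (a higher number here means a weaker inhibitor, a lower number a stronger inhibitor), compound 2 stands in the middle of these three numbers. Compound 4 `CN1C/C(=C\c2ccc(C(F)(F)F)cc2)C(=O)/C(=C/c2cccc([N+](=O)[O-])c2)C1`, not yet measured, has 3-nitrophenyl in place of 2-fluorophenyl on a double-bonded chain carbon bound to a double-bonded ring carbon. The measured steps are a 2.9-fold lower number from compound 1 to compound 2 (0.46 log units; beyond the scatter), a 2.4-fold lower number from compound 2 to compound 3 (0.38 log units; beyond the scatter) and a 6.8-fold lower number from compound 1 to compound 3 (0.83 log units; beyond the scatter). All are modest, but each swaps a group elsewhere, so none touches this place. They hint only at size and give no direction, so no clear shift in either direction is expected. The expected step is a 1.3-fold lower number from compound 2 to compound 4 (0.10 log units; within the scatter). For compound 4 the estimated value is 5000 nM, with an expected range from 1500 nM to 17000 nM.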

Compound 4, half-maximal inhibitory concentration: 4780 nM
The estimate for compound 4 lay 1.0-fold (0.02 log units) above the measured number, and the stated range covers the measured number.
By their numbers in this assay, from the lowest: compounds 3, 4 and 2 (each within the scatter of the next, the first and the last beyond it); then compound 1.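

In this assay, the first change shown at this place, 3-nitrophenyl in place of 2-fluorophenyl on a double-bonded chain carbon bound to a double-bonded ring carbon, gives a 1.3-fold lower number from compound 2 to compound 4 (0.12 log units; within the scatter). So this swap brings in more heavy atoms and hydrogen-bond acceptors, yet the two numbers cannot be told apart. No measurement on hand bears on why this is so.

As far as these compounds go, whether an amine or a carboxylic acid at this place would shift the number stays open. So does whether this swap would read the same with cyano or tert-butyl in place of trifluoromethyl.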